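The source may hold more compounds than are shown below. What is called first, only, known or untested is meant among the compounds shown, and "the series" means these compounds.

Among the measured compounds shown here, compound 2 `Fc1ccc(-c2cn3ccnc3c(-c3ccc4ncn(C5CCCCC5)c4c3)n2)cc1` stands lowest of the two numbers so far: in a functional assay on SN12C cells (Homo sapiens) for inhibition, read by sulforhodamine B assay, with a stated time of 48 h, tested at 10 uM (on this read-out higher numbers stand for more inhibition at the one concentration tested (going by the name of the read-out) and lower numbers for less inhibition), compound 2 gives 3.97%, while compound 1 `O=Cc1ccc(-c2cn3ccnc3c(-c3ccc4ncn(C5CCCCC5)c4c3)n2)cc1` gives 20.7%. For the measured compounds named here, the one measured step, a number 16.7 percentage points lower from compound 1 to compound 2 (beyond the scatter), covers fluoro in place of formyl. Compound 3 `CC(=O)c1ccc(-c2cn3ccnc3c(-c3ccc4ncn(C5CCCCC5)c4c3)n2)cc1` differs from compound 2 by acetyl in place of fluoro on an aromatic carbon. Going by the values given here, the entering acetyl shares the carbonyl of formyl, so the step from compound 1 to compound 2 is the only guide and points back upward. A rise of about a number 13 percentage points higher from compound 2 to compound 3 (beyond the scatter) is therefore expected for compound 3. Compound 3 is estimated at 17%, within 4% to 32%.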

Compound 3, a percentage reported as inhibition, at one concentration (the size of the read-out at that concentration, not a potency): 6.33%
Compound 3: the middle estimate sits 10.7 percentage points above what was measured; the measured number falls inside the stated range.
By their numbers in this assay, from the lowest: compounds 2 and 3 (each within the scatter of the next); then compound 1.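

Acetyl in place of fluoro gives a number 2.4 percentage points higher from compound 2 to compound 3 (within the scatter), while methyl in place of hydrogen on the carbonyl carbon gives a number 14.4 percentage points lower from compound 1 to compound 3 (beyond the scatter). A carbonyl at this position therefore does not by itself go with the higher number in this assay: the acetyl of compound 3 reads with the fluoro of compound 2, and only the formyl of compound 1 stands apart. No evidence on the cause of this difference is available.

Open, as far as these compounds go, is whether a carboxylic acid, an amine or a longer acyl chain such as propanoyl would read with formyl or with acetyl here.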